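The source may report more compounds than this note shows. Statements on the series, on what has been measured and on what is new or still open speak of the compounds shown alone.

Working notes on the series. Three compounds share one core and differ only at a single aromatic carbon. Compound 1 `CSc1nccc2c1ncn2C1O[C@H](CO)[C@@H](O)[C@H]1O` carries methylsulfanyl there; in a functional assay (Homo sapiens) for inhibition of Nucleic Acid, tested at 100 uM (on this read-out lower numbers stand for less inhibition and higher numbers for more inhibition at the one concentration tested (going by the name of the read-out)), compound 1 gives 24%. Compound 2 `OC[C@H]1OC(n2cnc3c(NCc4ccccc4)nccc32)[C@H](O)[C@@H]1O` carries benzylamino; in this assay compound 2 gives 32%, and the step of a number 8 percentage points higher from compound 1 to compound 2 (within the scatter) is small. Compound 3 `OC[C@H]1OC(n2cnc3c(S)nccc32)[C@H](O)[C@@H]1O` carries sulfanyl; in this assay compound 3 gives 6%, the lowest of the three numbers. The steps into it are both downward: a number 18 percentage points lower from compound 1 to compound 3 (beyond the scatter), and a number 26 percentage points lower from compound 2 to compound 3 (beyond the scatter).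

Compound 4 `OC[C@H]1OC(n2cnc3c(Cl)nccc32)[C@H](O)[C@@H]1O` is not yet measured. It differs from compound 3 as follows: chloro in place of sulfanyl on an aromatic carbon. Going by the values given here, no measured step makes this same exchange, so the bearing evidence is indirect: the two steps that alter the group at this carbon, a number 18 percentage points lower from compound 1 to compound 3 (beyond the scatter) and a number 26 percentage points lower from compound 2 to compound 3 (beyond the scatter), both end at compound 3 as the low point, so leaving sulfanyl for another small group is expected to give a modest upward step in this assay, roughly back toward the level of compound 1, though the scatter leaves room for no change. The expected step is a number 14 percentage points higher from compound 3 to compound 4 (beyond the scatter). Compound 4 is therefore estimated at 20%, between 0% and 42%.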

Compound 4, a percentage reported as inhibition, at one concentration (the size of the read-out at that concentration, not a potency): 76%
For compound 4 the middle estimate is 56 percentage points below the measured one; the measured number lies above the stated range.
By their numbers in this assay, from the lowest: compound 3; then compounds 1 and 2 (each within the scatter of the next); then compound 4.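

In this assay, going by these compounds alone, the group on this aromatic carbon, next to the ring nitrogen, matters far more than the earlier compounds could show: chloro gives a number 70 percentage points higher from compound 3 to compound 4 (beyond the scatter) and likewise a number 52 percentage points higher from compound 1 to compound 4 (beyond the scatter) and a number 44 percentage points higher from compound 2 to compound 4 (beyond the scatter) in the comparisons with the other two groups, which places compound 4 alone at the top of the four. The exchange of sulfanyl for chloro replaces 1 heavy atom with 1 heavy atom and touches no ring or net charge, so a step of this size does not depend on a larger group at this position; among the computed counts, only the hydrogen-bond donor and acceptor counts differ. No measurement available here accounts for the size of this step.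

On these data alone, whether the high number belongs to chloro alone or extends to fluoro, bromo or plain hydrogen at this carbon remains open, as does the outcome with a small carbon group such as methyl. Also open, as far as these compounds go, is whether a primary amine or a hydroxyl group here would fall with sulfanyl or rise with chloro.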